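This account rests on a few compounds, and the source may have more. Where it says the series, first, only, none or still open, it means among the compounds named here.

Measured compounds in the series:
Compound 1, `COc1ccc([C@H]2CC(=O)N(Cc3cccc([N+](=O)[O-])c3)C2)cc1OC1CCCC1`, in a functional assay on HEK293 cells (Homo sapiens) for cytotoxicity (a higher number here means that more compound is tolerated, a lower number that less compound is tolerated), gives > 10000 nM, which is a limit of the assay and not a number.
Compound 2, `COc1ccc([C@H]2CC(=O)N(c3ccc([S+](C)[O-])cc3)C2)cc1OC1CCCC1`, in this assay gives 7510 nM.
Compound 3, `COc1ccc([C@H]2CC(=O)N(c3cccc(NCC4CCOC4)c3)C2)cc1OC1CCCC1`, in this assay gives > 10000 nM, again a limit of the assay rather than a number.

Compound 3 therefore stands at the top of what this assay reports; only a bound is known for it. Going by the values given here, two of the three values sit at the limit of > 10000 nM in this assay, at which 2 of the 3 values shown sit, so the series as a whole is characterised by high tolerance, with compound 2 the only one that returns a number, and that number lies close to the bound.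

Compound 4, `COc1ccc([C@H]2CC(=O)N(c3cccc(NS(=O)(=O)c4ccccc4C)c3)C2)cc1OC1CCCC1`, differs from compound 3 in one place: (2-methylphenyl)sulfonyl in place of (oxolan-3-yl)methyl on a nitrogen on an aromatic ring. Among the compounds with values here, the single measured step, an at least 1.3-fold lower number from compound 1 to compound 2 (0.12 log units; that floor lies within the scatter), changes a group on an amide-type nitrogen in a ring, not the nitrogen on an aromatic ring altered here, and its floor lies within the scatter; it does not bear on the present change. Within the data shown here, no measured step speaks to exchanging (oxolan-3-yl)methyl for (2-methylphenyl)sulfonyl on the nitrogen on an aromatic ring.

Among the measured compounds shown here, with compound 3 at a limit and no relevant precedent, compound 4 is expected to stay at or near the limit, the step of a number no higher from compound 3 to compound 4 (the limit leaves the size open) being expected to show none beyond the scatter. The estimate for compound 4 in this assay is 10000 nM, within 4000 nM to 25000 nM.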

Compound 4, half-maximal cytotoxic concentration: > 10000 nM
Compound 4 gave a limit, no number; the forecaster's own chance of this, stated with the estimate: 60%; the middle value lies on the limit itself.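

In this assay compound 3 and compound 4 both stand at a limit of the assay and not at a number, so the step between them cannot be read: the limit of > 10000 nM in this assay, at which 3 of the 4 values shown sit.

The compounds shown leave open whether (2-methylphenyl)sulfonyl in place of (oxolan-3-yl)methyl on the nitrogen on an aromatic ring changes the tolerated concentration at all.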